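A few compounds are considered here, and "the series" means these few. Any claim that something is new, unique, unknown or untested is made for them only; others in the source may bear on it.

Measured compounds:
compound 1, `O=C(CN1C(=O)c2ccccc2C1=O)NN1C(=O)CSC1c1c(F)cccc1Cl`, 3.79
compound 2, `O=C(CN1C(=O)c2ccccc2C1=O)NN1C(=O)CSC1/C=C/c1ccccc1`, 3.65
compound 3, `O=C(CN1C(=O)c2ccccc2C1=O)NN1C(=O)CSC1c1ccc(O)cc1`, 2.4

In a physicochemical assay for lipophilicity, in phosphate buffer, measured as octanol-water partition, with a stated time of 24 h (on this read-out higher numbers stand for higher lipophilicity and lower numbers for lower lipophilicity), compound 3 stands lowest of the three, with compound 2 nearest at a number 1.25 log units lower from compound 2 to compound 3 (beyond the scatter) and compound 1 furthest at a number 1.39 log units lower from compound 1 to compound 3 (beyond the scatter). Compound 4, `COc1ccc(C2SCC(=O)N2NC(=O)CN2C(=O)c3ccccc3C2=O)cc1OC`, has not yet been measured. It differs from compound 3 thus: 3,4-dimethoxyphenyl in place of 4-hydroxyphenyl on a saturated ring carbon. Both large steps into compound 3 share the 4-hydroxyphenyl that now leaves, while the step of a number 0.14 log units lower from compound 1 to compound 2 (within the scatter) between the other two aryl groups stayed within the scatter. Among the compounds with values here, no measured step touches a methoxy group, so the size is uncertain, but compound 4 is expected to lie above compound 3 by a number 0.60 log units higher from compound 3 to compound 4 (beyond the scatter). In this assay the value of compound 4 is estimated at 3, within 2.5 to 3.5.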

Compound 4, partition coefficient: 2.78
Compound 4: middle estimate off by 0.22 log units, on the high side; the range from low to high includes it.
By their numbers in this assay, from the lowest: compound 3; then compound 4; then compounds 2 and 1 (each within the scatter of the next).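

In this assay the 3,4-dimethoxyphenyl group takes a middle place at this saturated ring carbon: it stands above the 4-hydroxyphenyl group (a number 0.38 log units higher from compound 3 to compound 4 (beyond the scatter)) but below the 2-phenylethenyl group (a number 0.87 log units lower from compound 2 to compound 4 (beyond the scatter)) and the 2-chloro-6-fluorophenyl group (a number 1.01 log units lower from compound 1 to compound 4 (beyond the scatter)). Within the data shown here, the earlier compounds showed only one low compound and a high pair, whereas this position now gives a graded spread. No measured evidence accounts for these steps. Left open is whether a single methoxy group, an amine or a carboxylic acid on the phenyl ring would fall within this spread.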